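Swapping an imidazolylmethyl for an acetylpyrrolidinyl group

This account rests on a few compounds, and the source may have more. Where it says the series, first, only, none or still open, it means among the compounds named here.

Of the compounds shown here, two sharing one core have been tested in an assay on isolated protein for binding affinity to secreted frizzled-related protein 1 (Homo sapiens), read by fluorescence; a higher number here means a weaker inhibitor, a lower number a stronger inhibitor. Compound 1 `O=C(Cn1ccnc1)N1CCC(NS(=O)(=O)c2cc(S(=O)(=O)c3ccccc3)ccc2C(F)(F)F)CC1` gives 30 nM, the lower of the two numbers. Compound 2 `CC(C)(C)OC(=O)N1C(=O)CC[C@H]1C(=O)N1CCC(NS(=O)(=O)c2cc(S(=O)(=O)c3ccccc3)ccc2C(F)(F)F)CC1` gives 130 nM in this assay, a higher number that lies beyond the usual scatter. Compound 3 `CC(=O)N1CCC[C@H]1C(=O)N1CCC(NS(=O)(=O)c2cc(S(=O)(=O)c3ccccc3)ccc2C(F)(F)F)CC1` has not yet been measured. Compared with compound 1 it carries 1-acetylpyrrolidin-2-yl in place of (1H-imidazol-1-yl)methyl on a carbonyl carbon. Within the data shown here, no measured pair shows exactly this change, but compound 2, which also places a five-membered nitrogen ring on that carbonyl carbon, gives 130 nM, so a modest move towards weaker binding seems likely, somewhere between no change and the gap seen there. The step from compound 1 to compound 3 is expected to be a 2.2-fold higher number from compound 1 to compound 3 (0.34 log units; beyond the scatter). Compound 3 is therefore estimated at 65 nM, with a range from 25 nM to 180 nM.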

Compound 3, half-maximal inhibitory concentration: 160 nM
For compound 3 the middle estimate is 2.5-fold (0.39 log units) below the measured one; measured number inside the range.
By their numbers in this assay, from the lowest: compound 1; then compounds 2 and 3 (each within the scatter of the next).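

In this assay the swap of (1H-imidazol-1-yl)methyl for 1-acetylpyrrolidin-2-yl on this carbonyl carbon gives a 5.3-fold higher number from compound 1 to compound 3 (0.73 log units; beyond the scatter) with the rest of the molecule unchanged, so the group at this position alone can shift the number beyond the scatter. The swap changes several things at once: an aromatic ring with two hetero atoms gives way to a non-aromatic ring with one, and an extra double bond outside the ring and a defined stereocentre appear, so the step cannot be assigned to any one of these features. Nothing in the available data explains the step.

Still open, on these data alone, is whether the opposite stereocentre would read the same. As far as these compounds go, it is also open whether an aminomethyl group or a carboxylic acid on this carbonyl carbon would sit nearer compound 1 or compound 3.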